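The compounds below may be only part of what the source reports. "The series", "measured", "known", "first", "only" and "open" are said of these compounds alone.

Compound 2 `C[C@@H](NC(=O)c1ccc(C#Cc2cc(F)cc(F)c2)cn1)C(C)(C)O` holds the highest of the three numbers in a functional assay on HEK293 cells for positive allosteric modulation of metabotropic glutamate receptor 5 (Rattus norvegicus), read by fluorescence and calcium flux (a higher number here means a larger maximal response, a lower number a smaller maximal response), giving 61.6%, although each step between the measured compounds is within the scatter: compound 1 `C[C@@H](NC(=O)c1ccc(C#Cc2ccccc2F)cn1)C(C)(C)O` gives 60% and compound 3 `Cc1ccccc1C#Cc1ccc(C(=O)N[C@H](C)C(C)(C)O)nc1` gives 59.9%. The steps were a number 1.6 percentage points higher from compound 1 to compound 2 (within the scatter), a number 1.7 percentage points lower from compound 2 to compound 3 (within the scatter) and a number 0.1 percentage points lower from compound 1 to compound 3 (within the scatter). Compound 4 `Cc1cccc(C#Cc2ccc(C(=O)N[C@H](C)C(C)(C)O)nc2)c1` differs from compound 2 thus: 3-methylphenyl in place of 3,5-difluorophenyl on a triple-bonded carbon. The step from compound 2 to compound 3 and the step from compound 1 to compound 3 bear on this change, and both were within the scatter, so no step beyond the scatter is expected in this assay. Compound 4 is therefore estimated at 60%, with a range from 52% to 68%, an expected step of a number 1.6 percentage points lower from compound 2 to compound 4 (within the scatter).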

Compound 4, largest response reached (reported as efficacy), in percent of the reference or control that the assay uses: 68.6%
Estimate against measurement, compound 4: 8.6 percentage points below; measured number outside the range, above it.
By their numbers in this assay, from the lowest: compounds 3, 1, 2 and 4 (each within the scatter of the next).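

In this assay, among these compounds, the change to 3-methylphenyl on a triple-bonded carbon gives the largest steps seen at this position so far (a number 7 percentage points higher from compound 2 to compound 4 (within the scatter)) and (a number 8.6 percentage points higher from compound 1 to compound 4 (within the scatter)). The pair that differs only in 3-methylphenyl against 2-methylphenyl gives a step of similar size (a number 8.7 percentage points higher from compound 3 to compound 4 (within the scatter)). Even so, no step among these four groups lies beyond the scatter, so the position has not yet separated any of them. On these data alone, whether an amine or a carboxylic acid on this phenyl ring would give a step beyond the scatter stays open. Nothing shown here offers an explanation for these steps.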